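From formyl to hydroxymethyl on compound 3

A few compounds are considered here, and "the series" means these few. Any claim that something is new, unique, unknown or untested is made for them only; others in the source may bear on it.

Measured in an ADME assay on HepG2 cells (Homo sapiens) for cytotoxicity, read by MTT assay, with a stated time of 72 h; a higher number here means that more compound is tolerated, a lower number that less compound is tolerated:
Compound 1 `O=[N+]([O-])c1c(CS(=O)(=O)c2ccccc2)nc2c(-c3ccccc3)cc(Cl)cn12` gives > 15600 nM as a limit
Compound 2 `COc1ccc(-c2cc(Cl)cn3c([N+](=O)[O-])c(CS(=O)(=O)c4ccccc4)nc23)cc1` gives > 3900 nM as a limit
Compound 3 `O=Cc1ccc(-c2cc(Cl)cn3c([N+](=O)[O-])c(CS(=O)(=O)c4ccccc4)nc23)cc1` gives > 31200 nM as a limit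

Compound 3 stands at > 31200 nM here, and that is a limit, as are the two other values. The change to compound 4 `O=[N+]([O-])c1c(CS(=O)(=O)c2ccccc2)nc2c(-c3ccc(CO)cc3)cc(Cl)cn12` is hydroxymethyl in place of formyl on an aromatic carbon and puts hydroxymethyl in place of formyl on an aromatic carbon. The measured steps a step that the two limits leave unreadable from compound 1 to compound 3 and a step that the two limits leave unreadable from compound 2 to compound 3 bear on it and give no size to carry over. In this assay no step beyond the scatter is therefore expected, the estimate being an at least 1.0-fold lower number from compound 3 to compound 4 (0.01 log units; that floor lies within the scatter) with no direction foreseen. For compound 4 the estimated concentration is 30000 nM with 10000 nM to 70000 nM as the expected range.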

Compound 4, half-maximal cytotoxic concentration: 13100 nM
The estimate for compound 4 lay 2.3-fold (0.36 log units) above the measured number; the measured number falls inside the stated range.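

In this assay, for the compounds shown here, compound 4 gives 13100 nM, the first number in this set that is not a limit, and the change from 4-formylphenyl to 4-(hydroxymethyl)phenyl gives an at least 2.3-fold lower number from compound 3 to compound 4 (0.37 log units; beyond the scatter). That size is only a floor because compound 3 carries a limit: the limit of > 31200 nM in this assay, at which 1 of the 4 values shown sits. Hydroxymethyl in place of hydrogen gives an at least 1.1-fold lower number from compound 1 to compound 4 (0.07 log units; that floor lies within the scatter), and the remaining steps among these compounds cannot be read.

From the compounds shown here alone, what stays open is how far the number moves at this position with an amine or a carboxylic acid, or with a longer chain ending in hydroxyl.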